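Working notes: from compound 3 to compound 4

A few compounds are considered here, and "the series" means these few. Any claim that something is new, unique, unknown or untested is made for them only; others in the source may bear on it.

Measured so far in a physicochemical assay for lipophilicity (a higher number here means a more lipophilic compound, a lower number a more polar compound), as follows
- compound 1 `Cc1nc(C)c(C(=O)Oc2ccc(-c3cc(=O)c4c(O)c(O)c(O)cc4o3)cc2)nc1C` at 3.01
- compound 2 `Cc1nc(C)c(COC(=O)COc2ccc(-c3cc(=O)c4c(O)c(O)c(O)cc4o3)cc2)nc1C` at 2.39
- compound 3 `Cc1nc(C)c(C(=O)NCC(=O)Oc2ccc(-c3cc(=O)c4c(O)c(O)c(O)cc4o3)cc2)nc1C` at 2.8

Compound 3 (2.8) lies within the scatter of compound 1 (3.01), while compound 2 (2.39) lies lower than compound 3 by more than the scatter. Compound 4 `Cc1nc(C)c(C(=O)N[C@@H](C(=O)Oc2ccc(-c3cc(=O)c4c(O)c(O)c(O)cc4o3)cc2)C(C)C)nc1C` differs from compound 3 by isopropyl in place of hydrogen on a saturated chain carbon bound to an amide-type nitrogen and a carbonyl carbon with isopropyl in place of hydrogen on a saturated chain carbon bound to an amide-type nitrogen and a carbonyl carbon. Going by the values given here, no measured pair isolates such a change, and the expectation rests on the structural change alone. In this assay a rise beyond the scatter is expected, and the estimated step is a number 0.80 log units higher from compound 3 to compound 4 (beyond the scatter) in size. Compound 4 is estimated at 3.6 with an expected range from 3.1 to 4.1 for this measurement.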

Compound 4, partition coefficient: 1.38
Beside the measured number, compound 4's estimate is 2.22 log units above it, and the stated range ends above it.
By their numbers in this assay, from the lowest: compound 4; then compound 2; then compounds 3 and 1 (each within the scatter of the next).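

In this assay, isopropyl in place of hydrogen on a saturated chain carbon bound to an amide-type nitrogen and a carbonyl carbon gives a number 1.42 log units lower from compound 3 to compound 4 (beyond the scatter), the first step read at this position. The entering group brings 3 heavy atoms, all carbon, with no ring and no net charge, yet the number falls. Nothing in the data at hand bears on why.

Open, going by these compounds, is whether this fall belongs to isopropyl alone or to any group replacing that hydrogen. A methyl, a longer chain or an amine at this place would separate the two.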